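Acetylating the amino group of compound 2

A few compounds are considered here, and "the series" means these few. Any claim that something is new, unique, unknown or untested is made for them only; others in the source may bear on it.

Within the data shown here, in a functional assay on A498 cells (Homo sapiens) for cytotoxicity, read by sulforhodamine B assay, with a stated time of 48 h (a lower number here means a stronger inhibitor of growth, a higher number a weaker inhibitor of growth), compound 1 `COc1ccc(C(=O)c2cc(OC)c(OC)c(OC)c2)c(OC)c1O` gives 2720 nM, while compound 2 `COc1ccc(C(=O)c2cc(OC)c(OC)c(OC)c2)c(OC)c1N` gives 22.1 nM, the lower of the two numbers so far. Next comes compound 3 `COc1ccc(C(=O)c2cc(OC)c(OC)c(OC)c2)c(OC)c1NC(C)=O`, with the change acetyl in place of hydrogen on a nitrogen on an aromatic ring, amino to acetamido. Among the measured compounds shown here, only one measured step bears on this, and only indirectly: amino in place of hydroxy on an aromatic carbon gave a 120-fold lower number from compound 1 to compound 2 (2.09 log units; beyond the scatter), a large step. A smaller step towards a higher number is therefore expected. The estimated step is a 14-fold higher number from compound 2 to compound 3 (1.13 log units; beyond the scatter). For compound 3 the expected value is 300 nM, with an estimated range of 50 nM to 2500 nM.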

Compound 3, concentration for 50% growth inhibition: 85.5 nM
For compound 3 the middle estimate is 3.5-fold (0.55 log units) above the measured one; low and high end bracket the measured number.
By their numbers in this assay, from the lowest: compound 2; then compound 3; then compound 1.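

Acetyl on this aromatic nitrogen costs only a modest part of the potency in this assay (a 3.9-fold higher number from compound 2 to compound 3 (0.59 log units; beyond the scatter)). Most of the advantage over the hydroxy compound remains (a 32-fold lower number from compound 1 to compound 3 (1.50 log units; beyond the scatter)), so at this position the advantage does not depend on a free amino group. No measurement available here accounts for either step.

Open, from the compounds shown here alone, is whether a longer acyl chain, a methanesulfonyl group or a single methyl on this nitrogen would fall nearer compound 2 or compound 3. Also open, going by these compounds, is whether a nitrogen-free group, such as fluorine, could match any of the nitrogen-bearing compounds.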